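One aromatic ring swapped at the assay limit

The source may hold more compounds than are shown below. What is called first, only, known or untested is meant among the compounds shown, and "the series" means these compounds.

In an ADME assay on SW1353 cells (Homo sapiens) for cytotoxicity, read by a luciferase reporter, with a stated time of 30 min (on this read-out higher numbers stand for lower toxicity in this test and lower numbers for higher toxicity in this test), compound 1 `CCCN(C(=O)c1ccc(-c2ccc(Cl)cc2)o1)c1ccc(N2CCNCC2)cc1` reads > 20000 nM as a limit and not a number. Compound 2 `CC(C)N(C(=O)c1ccc(-c2ccc(Cl)cc2)o1)c1ccc(N2CCNCC2)cc1` reads > 20000 nM which is likewise a limit. Compound 3 `Cn1ccnc1CN(C(=O)c1ccc(-c2ccc(Cl)cc2)o1)c1ccc(N2CCNCC2)cc1` reads > 20000 nM which is again only a limit. Compound 4 `O=C(c1ccc(-c2ccc(Cl)cc2)o1)N(Cc1ccncc1)c1ccc(N2CCNCC2)cc1` carries pyridin-4-yl in place of 1-methyl-1H-imidazol-2-yl on a saturated chain carbon bound to an amide-type nitrogen. The steps bearing on this change are a step that the two limits leave unreadable from compound 1 to compound 3 and a step that the two limits leave unreadable from compound 2 to compound 3, and also a step that the two limits leave unreadable from compound 1 to compound 2, so none gives a size. No step beyond the scatter is therefore expected in this assay, and the estimated move is a number no higher from compound 3 to compound 4 (the limit leaves the size open). Compound 4 is expected near 20000 nM, within an estimated range from 10000 nM to 40000 nM.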

Compound 4, half-maximal cytotoxic concentration: > 8000 nM
Compound 4: no number, only a limit (the forecaster's own chance of this, stated with the estimate: 85%); the middle value is on the limit's open side.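

Compound 4, like compound 1, compound 2 and compound 3, gives only a limit in this assay, so no step among these compounds can be read. Going by these compounds, how far apart the four compounds truly lie remains open.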